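Halogen exchange on the benzyl group of compound 2

The compounds below may be only part of what the source reports. "The series", "measured", "known", "first", "only" and "open" are said of these compounds alone.

- Compound 1 `COc1cc(OC)c(-c2coc3cc(OCc4cccc(F)c4)ccc3c2=O)cc1OC`: 1230 nM
- Compound 2 `COc1cc(OC)c(-c2coc3cc(OCc4ccccc4Cl)ccc3c2=O)cc1OC`: 1690 nM

Both compounds were measured in a functional assay on HepG2 cells (Homo sapiens) for antiproliferative activity, read by MTT assay, with a stated time of 24 h; on this read-out lower numbers stand for stronger inhibition and higher numbers for weaker inhibition. Compound 2 stands at 1690 nM, level with compound 1 once the scatter is allowed for.

The next compound is compound 3 `COc1cc(OC)c(-c2coc3cc(OCc4ccccc4Br)ccc3c2=O)cc1OC`. The change from compound 2 is bromo in place of chloro on an aromatic carbon, ortho to a large group. The rest of the structure stays the same, so the difference reads as 2-chlorobenzyl to 2-bromobenzyl.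

For the measured compounds named here, only one measured step bears on this change: a 1.4-fold higher number from compound 1 to compound 2 (0.14 log units; within the scatter). That step exchanged 3-fluorophenyl for 2-chlorophenyl and stayed within the scatter. Going by the values given here, no measured pair yet exchanges chloro for bromo, so the evidence is thin. No shift beyond the scatter is expected in either direction in this assay.

The expected change is a 1.1-fold lower number from compound 2 to compound 3 (0.02 log units; within the scatter). For compound 3 the estimated value is 1600 nM, with an expected range of 850 nM to 3000 nM.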

Compound 3, half-maximal inhibitory concentration: 2180 nM
Estimate against measurement, compound 3: 1.4-fold (0.13 log units) below; the range from low to high includes it.
By their numbers in this assay, from the lowest: compounds 1, 2 and 3 (each within the scatter of the next).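

In this assay the exchange of chloro for bromo at this position can now be read directly, and it gives a 1.3-fold higher number from compound 2 to compound 3 (0.11 log units; within the scatter) with the rest of the structure unchanged. On this evidence, 2-chlorobenzyl and 2-bromobenzyl are not separated by this read-out, with the halogen ortho to a large group in both compounds. The step between 3-fluorophenyl and 2-bromophenyl, which changes both the halogen and its place, gives a 1.8-fold higher number from compound 1 to compound 3 (0.25 log units; within the scatter) and so also leaves the three compounds level, with none standing out as the most potent. No measurement at hand offers an explanation for how little these values differ.

As far as these compounds go, it remains open whether a plain benzyl group without any halogen would read differently from these three compounds, so the contribution of the halogen itself is still unknown. Also open, from the compounds shown here alone, is whether a nitrile, an amine or a carboxylic acid in the place of the halogen would move the value beyond the scatter.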